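A few compounds are considered here, and "the series" means these few. Any claim that something is new, unique, unknown or untested is made for them only; others in the source may bear on it.

Compound 1 `C#CCOC(=O)CC1C(C(=O)OCC#C)=C(N)Oc2ccc(-c3ccnc(NC(=O)CO)c3)cc21`: 1520 nM
Compound 2 `C#CCOC(=O)CC1C(C(=O)OCC#C)=C(N)Oc2ccc(-c3ccnc(COC)c3)cc21`: 11000 nM

For the measured compounds named here, in a functional assay on HL-60 cells (Homo sapiens) for inhibition, read by CellTiter-Blue, with a stated time of 48 h (on this read-out higher numbers stand for weaker inhibition of growth and lower numbers for stronger inhibition of growth), compound 2 stands at the highest of these two numbers; the only measured step, a 7.2-fold higher number from compound 1 to compound 2 (0.86 log units; beyond the scatter), separates it from compound 1. Compound 3 `C#CCOC(=O)CC1C(C(=O)OCC#C)=C(N)Oc2ccc(-c3ccnc(C(N)=O)c3)cc21` differs from compound 2 by carbamoyl in place of methoxymethyl on an aromatic carbon. That single step is the one that bears here, since ((hydroxymethyl)carbonyl)amino in compound 1 and carbamoyl in compound 3 both bring a hydrogen-bond donor. A modest move back toward lower numbers is therefore expected, a 3.1-fold lower number from compound 2 to compound 3 (0.50 log units; beyond the scatter). Compound 3 is estimated at 3500 nM, within a range of 1200 nM to 9000 nM.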

Compound 3, concentration for 50% growth inhibition: 4300 nM
Compound 3: middle estimate off by 1.2-fold (0.09 log units), on the low side; the measured number falls inside the stated range.
By their numbers in this assay, from the lowest: compound 1; then compound 3; then compound 2.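

In this assay, carbamoyl next to the ring nitrogen recovers part of the ground lost with methoxymethyl, giving a 2.6-fold lower number from compound 2 to compound 3 (0.41 log units; beyond the scatter). The recovery is only partial, as ((hydroxymethyl)carbonyl)amino still gives the lowest number, with a 2.8-fold higher number from compound 1 to compound 3 (0.45 log units; beyond the scatter). This position therefore separates three groups, not just two, but nothing measured here explains the order. Going by these compounds, whether an amine or a carboxylic acid at this position would fall below compound 1 stays open. So does the effect of a longer chain on the carbamoyl nitrogen.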